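Moving the Chlorine Around the Benzoyl Ring of Compound 3

The compounds below may be only part of what the source reports. "The series", "measured", "known", "first", "only" and "open" are said of these compounds alone.

Of the compounds shown here, three sharing one core have been measured in a functional assay on NCI-H23 cells (Homo sapiens) for cytotoxicity, read by sulforhodamine B assay, with a stated time of 72 h; on this read-out lower numbers stand for stronger inhibition of growth and higher numbers for weaker inhibition of growth. Compound 1 `O=C(Nc1ccccc1C(F)(F)F)C1CCc2ccccc2N1C(=O)c1cccc(Cl)c1` gives 292 nM. Compound 2 `O=C(Nc1ccccc1)C1CCc2ccccc2N1`, which carries no group on the ring nitrogen, gives 97100 nM. Compound 3 `O=C(Nc1cc(C(F)(F)F)cc(C(F)(F)F)c1)C1CCc2ccccc2N1C(=O)c1ccc(Cl)cc1` gives 889 nM; it stands second highest of the three, sitting beyond the scatter above compound 1 and far below compound 2.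

Compound 4 `O=C(Nc1cc(C(F)(F)F)cc(C(F)(F)F)c1)C1CCc2ccccc2N1C(=O)c1ccccc1Cl` differs from compound 3 in one respect: 2-chlorophenyl in place of 4-chlorophenyl on a carbonyl carbon. For the measured compounds named here, no measured pair shows this change on its own. The data do show that a chlorophenyl on the carbonyl, in any arrangement seen so far, keeps the number far below that of compound 2, and compound 1 shows a chlorine placed differently from compound 3 giving a lower number. Compound 4 is therefore expected to land near compound 3, at about 700 nM, with a range from 250 nM to 2000 nM. The expected step, a 1.3-fold lower number from compound 3 to compound 4 (0.10 log units; within the scatter), is estimated to be small and close to the scatter.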

Compound 4, concentration for 50% growth inhibition: 2080 nM
The estimate for compound 4 lay 3.0-fold (0.47 log units) below the measured number; measured number above the stated range.
By their numbers in this assay, from the lowest: compound 1; then compound 3; then compound 4; then compound 2.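

In this assay, swapping 4-chlorophenyl for 2-chlorophenyl on the carbonyl carbon, with the rest of the molecule unchanged, gives a 2.3-fold higher number from compound 3 to compound 4 (0.37 log units; beyond the scatter), so growth inhibition weakens modestly. For the compounds shown here, this is the first pair here that isolates where the chlorine sits on this ring: compound 1 also carries a chlorine placed differently from compound 3, but it differs from compound 3 on its other aromatic ring too, so it could not settle the point. Nothing measured here explains why the two arrangements differ.

From the compounds shown here alone, whether the same swap would give a step of similar size with the trifluoromethyl-bearing ring of compound 1 remains open. Also open, going by these compounds, is what an amine or a carboxylic acid would do in place of the chlorine on this ring.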